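One group swapped on an amide nitrogen

The compounds below may be only part of what the source reports. "The series", "measured", "known", "first", "only" and "open" are said of these compounds alone.

Measured in a physicochemical assay for solubility, read by nephelometry, measured as kinetic solubility, at pH 6.5; on this read-out lower numbers stand for lower solubility and higher numbers for higher solubility:
- Compound 1 `NCc1csc(NC(=O)c2ncccn2)n1`: > 100 ug/mL, a limit and not a number
- Compound 2 `CC(C)(C)c1cc(C(=O)Nc2ccccn2)n(Cc2ccccc2)n1`: 6.3 ug/mL

Going by the values given here, compound 2 gives the only actual number so far in this assay, at 6.3 ug/mL.

Compound 3 `CNCc1csc(NC(=O)c2cc(C(C)(C)C)nn2Cc2ccccc2)n1` differs from compound 2 in one place: 4-((methylamino)methyl)-1,3-thiazol-2-yl in place of pyridin-2-yl on an amide-type nitrogen. In words, 4-((methylamino)methyl)-1,3-thiazol-2-yl stands in place of pyridin-2-yl on an amide-type nitrogen.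

Among the compounds with values here, no measured pair shows this change, so the size of the step is a judgement. The expectation of a rise in this assay, clearly beyond the usual scatter, leans on compound 1, whose reading of > 100 ug/mL is a limit. The estimated change a 7.9-fold higher number from compound 2 to compound 3 (0.90 log units; beyond the scatter) is therefore expected to be upward. For compound 3 the estimate is 50 ug/mL, with an expected range of 15 ug/mL to 100 ug/mL.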

Compound 3, solubility: 12.5 ug/mL
Compound 3: middle estimate off by 4.0-fold (0.60 log units), on the high side, and the stated range ends above it.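

In this assay, putting 4-((methylamino)methyl)-1,3-thiazol-2-yl in place of pyridin-2-yl on the amide-type nitrogen gives a 2.0-fold higher number from compound 2 to compound 3 (0.30 log units; within the scatter). This position therefore accepts a group with more heavy atoms, a hydrogen-bond donor and more hydrogen-bond acceptors, yet this read-out does not separate the two compounds. Compound 1 differs from compound 3 in more than one place and its reading is a limit and not a number, and no step to it can be read: the limit of > 100 ug/mL in this assay, at which 1 of the 3 values shown sits.

Still open, on these data alone, is what each part of the new group contributes, which a plain 1,3-thiazol-2-yl group, without the (methylamino)methyl chain, would help to separate. Also open, as far as these compounds go, is how a dimethylamino or a carboxylic acid in place of the methylamino part would read in this assay.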